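The source may hold more compounds than are shown below. What is called first, only, known or untested is meant among the compounds shown, and "the series" means these compounds.

Measured so far in an ADME assay on MOLT-3 cells (Homo sapiens) for cytotoxicity, with a stated time of 7 days; a lower number here means that less compound is tolerated, a higher number that more compound is tolerated:
- compound 1, `Nc1nc(NC2CCCCC2)c2ncn(/C=C3/CC3(CO)CO)c2n1`: "not determined" (no result reported)
- compound 2, `CCCOc1nc(N)nc2c1ncn2/C=C1/CC1(CO)CO`: > 20000 nM, which is a limit of this assay and not a number
- compound 3, `Nc1nc2c(ncn2/C=C2/CC2(CO)CO)c(=O)[nH]1`: > 20000 nM, which is again a limit of this assay rather than a number

Compound 2 thus stands with no single number of its own in this assay; its value is only a limit, and the same holds for compound 3, so two of the three values shown sit at the limit of > 20000 nM in this assay, at which 2 of the 3 values shown sit, while compound 1 has no result at all. Within the data shown here, there is no pair of measured compounds that differ in one place, so no measured step is available to show how large a change of this kind moves the read-out.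

Compound 4, `CCCCCCCCSc1nc(N)nc2c1ncn2/C=C1/CC1(CO)CO`, differs from compound 2 in one place: octylsulfanyl in place of propoxy on an aromatic carbon. With both measured neighbours sitting at the limit, nothing in the data points in either direction, and the expectation is a step from compound 2 to compound 4 of a number no higher from compound 2 to compound 4 (the limit leaves the size open), that is, none beyond the scatter. For compound 4 the estimated value in this assay is 20000 nM, with an expected range from 4000 nM to 60000 nM, and a fair chance that only a limit will again be reported.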

Compound 4, half-maximal cytotoxic concentration: > 20000 nM
Compound 4: no number, only a limit; the forecaster's own chance of this, stated with the estimate: 55%; the middle value sits exactly at the limit.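

In this assay, compound 2 and compound 4 each give only a limit and not a number, so no step can be read for octylsulfanyl in place of propoxy on an aromatic carbon. One limit dominates the values shown: the limit of > 20000 nM in this assay, at which 3 of the 4 values shown sit.

With no single number for any compound shown, it remains open whether a change at this place moves the read-out at all.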